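The source may hold more compounds than are shown below. What is called first, only, known or untested is meant among the compounds shown, and "the series" means these compounds.

Measured compounds:
- compound 1, `CC(C)COc1cc(C(F)(F)F)nn1-c1ccc(S(C)(=O)=O)cc1`: "not determined" (no result reported)
- compound 2, `CC(C)COc1c(C#N)c(C(F)(F)F)nn1-c1ccc(S(C)(=O)=O)cc1`: "not determined" (no result reported)
- compound 3, `CS(=O)(=O)c1ccc(-n2nc(C(F)(F)F)cc2OC2CCCC2)cc1`: 25 ug/mL

Three compounds sharing a common core were examined in a physicochemical assay for solubility; on this read-out higher numbers stand for higher solubility and lower numbers for lower solubility. For compound 1 and compound 2 no result was reported, so neither contributes a number. Compound 3 therefore stands alone: in this assay compound 3 gives 25 ug/mL, and this is the only figure available for the series. Within the data shown here, with a single measured value there is no step between measured compounds to learn from, and no pattern can be drawn from compound 3 by itself.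

The next compound, compound 4, has the structure `CS(=O)(=O)c1ccc(-n2nc(C(F)(F)F)cc2OCC2CCC2)cc1`. It differs from compound 3 in one place: cyclobutylmethyl in place of cyclopentyl on an oxygen on an aromatic ring. The two compounds are built from the same atoms joined differently, and the change swaps one small carbon ring for another of the same size in atom count. Among the measured compounds shown here, with no measured step to guide the size of the effect, the expectation is that the step of no change at the digits printed from compound 3 to compound 4 (within the scatter) stays within the usual scatter of repeated measurements, in no particular direction. On that basis compound 4 is estimated to give 25 ug/mL in this assay, with a plausible range from 10 ug/mL to 60 ug/mL.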

Compound 4, solubility: 25 ug/mL
Estimate against measurement, compound 4: no gap at the digits printed; the measured number falls inside the stated range.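

In this assay the series now has its first readable step, which is no change at the digits printed from compound 3 to compound 4 (within the scatter) and comes with cyclobutylmethyl in place of cyclopentyl on an oxygen on an aromatic ring. The two groups have the same count of heavy atoms, all of them carbon, and each holds one non-aromatic ring, so the change amounts to a five-membered ring traded for a four-membered one. At this position, that particular rearrangement of the same atoms leaves no mark on this read-out, though this is one pair of compounds and not a general rule. Nothing measured here speaks to why the result came out this way.

From the compounds shown here alone, both groups are built of carbon alone, so it remains open whether the read-out would move with a different kind of group at this oxygen, such as one carrying an amine or a carboxylic acid, or with a longer chain. Compound 1 and compound 2 have no reported result, so the effect of the nitrile in compound 2 also stays unread.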